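The source may hold more compounds than are shown below. What is called first, only, known or untested is meant among the compounds shown, and "the series" means these compounds.

Measured so far in a functional assay on T47D cells (Homo sapiens) for cytotoxicity, read by CCK-8 assay; a higher number here means a weaker inhibitor, a lower number a stronger inhibitor:
compound 1, `Oc1cccc(-c2cc(-c3cccs3)cc(-c3ccccc3O)n2)c1`, > 50000 nM;
compound 2, `Oc1ccc(-c2cc(-c3cccs3)cc(-c3ccccc3O)n2)cc1`, > 50000 nM;
compound 3, `Oc1cccc(-c2cc(-c3cccnc3)cc(-c3ccccc3O)n2)c1`, 6230 nM.

The value for compound 1 is a limit of the assay, not a number. The value for compound 2 is likewise a limit. Compound 3 is the only one of the three with a number. Compound 3 differs from compound 1 by pyridin-3-yl in place of thiophen-2-yl on an aromatic carbon, and that step is an at least 8.0-fold lower number from compound 1 to compound 3 (0.90 log units; beyond the scatter), its size bounded only because of the limit of > 50000 nM in this assay, at which 2 of the 3 values shown sit. Compound 2 differs from compound 1 by 4-hydroxyphenyl in place of 3-hydroxyphenyl on an aromatic carbon, and that step is a step that the two limits leave unreadable from compound 1 to compound 2. Compound 4, `Oc1ccc(-c2cc(-c3cccnc3)cc(-c3ccccc3O)n2)cc1`, has not been measured; it differs from compound 3 by 4-hydroxyphenyl in place of 3-hydroxyphenyl on an aromatic carbon. This is the same kind of change as that from compound 1 to compound 2, but the surroundings differ: in compound 1 the site is meta to a thiophen-2-yl group (5 heavy atoms), in compound 3 meta to a pyridin-3-yl group (6 heavy atoms). The earlier step gives no readable size, so the expected step is a 1.6-fold higher number from compound 3 to compound 4 (0.21 log units; within the scatter). That expectation rests only on the one number shown, which compound 3 gives in this assay as 6230 nM. Compound 4 is expected to give about 10000 nM, between 2500 nM and 50000 nM.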

Compound 4, half-maximal inhibitory concentration: > 50000 nM
Compound 4 was reported as a limit; the forecaster's own chance of this, stated with the estimate: 35%; at least 5.0-fold (0.69 log units) between middle value and limit.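

On the core carrying pyridin-3-yl, 4-hydroxyphenyl in place of 3-hydroxyphenyl gives in this assay an at least 8.0-fold higher number from compound 3 to compound 4 (0.90 log units; beyond the scatter), so on this core the placing of the hydroxyl on that phenyl ring matters beyond the scatter. Compound 4 gives > 50000 nM as a limit of the assay and not a number, and the step has a bound rather than a size because of that limit: the limit of > 50000 nM in this assay, at which 3 of the 4 values shown sit. The same change on the core carrying thiophen-2-yl, from compound 1 to compound 2, cannot be read, and neither can the step from compound 2 to compound 4, since both ends of each are limits, so the result shows the effect on one core only and does not show that it carries over to another.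

Going by these compounds, it stays open how a methoxy group, an amine or a carboxylic acid in place of that hydroxyl would read in this assay. Also open, on these data alone, is whether a group other than pyridin-3-yl, such as a morpholine, would bring the core of compound 1 to a number.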